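Halogen swap at the fused ring: chloro to bromo

This account rests on a few compounds, and the source may have more. Where it says the series, first, only, none or still open, it means among the compounds named here.

Measured compounds:
- Compound 1 `Fc1ccc2[nH]nc(Nc3cccc(Cl)c3)c2c1`: 58 nM
- Compound 2 `Clc1cccc(Nc2n[nH]c3ccc(Cl)cc23)c1`: 5 nM

In an assay for inhibition of acyl-CoA (8-3)-desaturase (Homo sapiens) (a lower number here means a stronger inhibitor, a higher number a weaker inhibitor), compound 1 gives 58 nM, and compound 2 gives 5 nM. Going by the values given here, compound 2 therefore stands at the lowest of the two numbers so far, its only neighbour being compound 1, a 12-fold lower number from compound 1 to compound 2 (1.06 log units; beyond the scatter). That single step is the one that bears on the next change, since it too is a halogen exchange on the same carbon of the shared core.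

Compound 3 `Clc1cccc(Nc2n[nH]c3ccc(Br)cc23)c1` is not yet measured in this assay. It differs from compound 2 as bromo in place of chloro on an aromatic carbon. Among the compounds with values here, with only one related step on record, and that step large, the expectation is for a smaller move in the same direction, because the gain seen as a 12-fold lower number from compound 1 to compound 2 (1.06 log units; beyond the scatter) may not repeat in full. Compound 3 is thus expected at 3 nM, with a range from 1 nM to 12 nM, meaning an estimated step of a 1.7-fold lower number from compound 2 to compound 3 (0.22 log units; within the scatter).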

Compound 3, half-maximal inhibitory concentration: 21 nM
Estimate against measurement, compound 3: 7.0-fold (0.85 log units) below; the measured number lies above the stated range.
By their numbers in this assay, from the lowest: compound 2; then compound 3; then compound 1.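

In this assay, the response at this aromatic carbon does not run in one direction through the halogens: replacing chloro with bromo reverses the earlier gain, with a 4.2-fold higher number from compound 2 to compound 3 (0.62 log units; beyond the scatter). Bromo still keeps part of the advantage over fluoro, with a 2.8-fold lower number from compound 1 to compound 3 (0.44 log units; beyond the scatter), so among these three compounds chloro gives the lowest number and bromo falls between chloro and fluoro. Nothing measured here explains why the number turns upward at bromo.

The compounds shown leave open how a methyl, a methoxy or an amine on this same carbon would compare with chloro. They also do not show whether the same halogen order would hold if the chloro on the other aromatic ring were replaced by a methyl.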